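The source may report more compounds than this note shows. Statements on the series, on what has been measured and on what is new or still open speak of the compounds shown alone.

Measured so far in an ADME assay on Vero cells (Chlorocebus sabaeus) for cytotoxicity, read by MTT assay, with a stated time of 72 h; a lower number here means a stronger inhibitor, a higher number a weaker inhibitor:

compound 1 `COc1cccc(-c2csc(NC(=O)c3ccc([N+](=O)[O-])cc3)n2)c1`: > 90000 nM, which is a limit of the assay, not a number.
compound 2 `COc1ccccc1-c1csc(NC(=O)c2ccc([N+](=O)[O-])o2)n1`: 42000 nM.
compound 3 `O=C(Nc1nc(-c2cccc(Cl)c2)cs1)c1ccc([N+](=O)[O-])o1`: 43700 nM.

Compound 3 and compound 2 lie within the scatter of each other, so neither stands apart. Compound 1 sits at the limit of > 90000 nM in this assay, at which 1 of the 3 values shown sits.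

Compound 4 `CC(=O)Nc1cccc(-c2csc(NC(=O)c3ccc([N+](=O)[O-])o3)n2)c1` differs from compound 3 by acetamido in place of chloro on an aromatic carbon. Among the compounds with values here, the only measured step on that phenyl ring, a 1.0-fold higher number from compound 2 to compound 3 (0.02 log units; within the scatter), stayed within the scatter, so a change on this ring has so far left this assay unmoved, and no step beyond the scatter is expected here either. Compound 4 is therefore expected near 42000 nM, between 20000 nM and 90000 nM. That corresponds to an expected step of a 1.0-fold lower number from compound 3 to compound 4 (0.02 log units; within the scatter).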

Compound 4, half-maximal inhibitory concentration: 57600 nM
For compound 4 the middle estimate is 1.4-fold (0.14 log units) below the measured one; the range from low to high includes it.
By their numbers in this assay, from the lowest: compounds 2, 3 and 4 (each within the scatter of the next). At a limit, above all of these: compound 1.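

In this assay, acetamido in place of chloro on the same aromatic carbon, meta to a large group, stays within the scatter: a 1.3-fold higher number from compound 3 to compound 4 (0.12 log units; within the scatter). This adds a hydrogen-bond donor, a hydrogen-bond acceptor and more heavy atoms at a single position, without a step beyond the scatter, which the earlier step, where the substituent also changed position, could not show. Compound 1 remains the only compound given as a limit: the limit of > 90000 nM in this assay, at which 1 of the 4 values shown sits.

Going by these compounds, whether an amine, a carboxylic acid or a longer chain on this carbon would also leave the number within the scatter stays open. So does any change away from this phenyl ring, since no step on the rest of the core can be read.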